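Carboxy to methoxymethoxymethyl on the large ring

A few compounds are considered here, and "the series" means these few. Any claim that something is new, unique, unknown or untested is made for them only; others in the source may bear on it.

Compound 1 `CC(C)=CCC[C@]1(C)/C=C/[C@@H](OC(=O)C=C(C)C)[C@](C)(O)/C=C/C(=O)/C(C(=O)O)=C\C1` carries a carboxy group on a double-bonded ring carbon of its core. In a functional assay on A549 cells (Homo sapiens) for antiproliferative activity, read by MTT assay, with a stated time of 48 h (on this read-out higher numbers stand for weaker inhibition and lower numbers for stronger inhibition), compound 1 returns only a limit, > 10000 nM, and not a number; the reading sits at the limit of > 10000 nM in this assay, at which 1 of the 2 values shown sits. Compound 2 `CC(C)=CCC[C@]1(C)/C=C/[C@@H](OC(=O)C=C(C)C)[C@](C)(O)/C=C/C(=O)/C(C[Si](c2ccccc2)(c2ccccc2)C(C)(C)C)=C\C1`, with a silyl substituent at that position, gives 13000 nM in this assay, so both measured members of the series stand at the weak end of the range. Compound 3 `COCOC/C1=C/C[C@](C)(CCC=C(C)C)/C=C/[C@@H](OC(=O)C=C(C)C)[C@](C)(O)/C=C/C1=O` is the next member to be measured. It differs from compound 1 by (methoxymethoxy)methyl in place of carboxy on a double-bonded ring carbon. Among the measured compounds shown here, no measured step of this kind exists, so the direction rests on the two weak readings alone; a modest gain in potency is expected, of the size an at least 1.2-fold lower number from compound 1 to compound 3 (0.09 log units; that floor lies within the scatter). For compound 3 the expected value in this assay is 8000 nM, estimated to lie between 2000 nM and 30000 nM.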

Compound 3, half-maximal inhibitory concentration: 2980 nM
Compound 3: middle estimate off by 2.7-fold (0.43 log units), on the high side; low and high end bracket the measured number.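

In this assay, replacing carboxy with (methoxymethoxy)methyl on the double-bonded ring carbon gives an at least 3.3-fold lower number from compound 1 to compound 3 (0.52 log units; beyond the scatter), so this position can move the read-out, which the two earlier weak readings did not show. With compound 2 at 13000 nM and compound 3 at 2980 nM, the printed values also show that replacing carboxy does not by itself fix the reading, and that the group which enters matters. Compound 1 gives a limit and not a number, so the size of the step is only a floor: the limit of > 10000 nM in this assay, at which 1 of the 3 values shown sits.

The compounds shown do not separate the loss of the hydrogen-bond donor from the gain of the (methoxymethoxy)methyl chain. From the compounds shown here alone, how a hydroxymethyl group, a methyl ester or an amine at this carbon would read in this assay stays open.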